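A few compounds are considered here, and "the series" means these few. Any claim that something is new, unique, unknown or untested is made for them only; others in the source may bear on it.

Of the compounds shown here, three have been tested in a functional assay on MCF7 cells (Homo sapiens) for inhibition, read by MTT assay, with a stated time of 72 h; on this read-out higher numbers stand for weaker inhibition and lower numbers for stronger inhibition. Compound 1 `CNc1nc(C)c(C(=O)N/N=C/c2ccccc2C(F)(F)F)s1` gives only a limit of the assay, > 100 ug/mL. Compound 2 `CNc1nc(C)c(C(=O)N/N=C/c2cccc(C(F)(F)F)c2)s1` likewise gives only a limit, > 100 ug/mL. For the measured compounds named here, compound 3 `CN(C(=O)NC(=O)c1ccccc1F)c1nc(C(F)(F)F)c(C(=O)N/N=C/c2cc(C(F)(F)F)cc(C(F)(F)F)c2)s1` is the single compound with a measured number in this assay, 6.16 ug/mL, and so it is the only fixed point on which an expectation can rest. Beyond that, the data show (the limit of > 100 ug/mL in this assay, at which 2 of the 3 values shown sit). Compound 4 `CN(C(=O)NC(=O)c1ccc(Cl)cc1Cl)c1nc(C(F)(F)F)c(C(=O)N/N=C/c2cc(C(F)(F)F)cc(C(F)(F)F)c2)s1` is not yet measured; it differs from compound 3 by 2,4-dichlorophenyl in place of 2-fluorophenyl on a carbonyl carbon, with the rest of the structure unchanged. Going by the values given here, no measured pair shows such a change, so the step of a 1.1-fold lower number from compound 3 to compound 4 (0.05 log units; within the scatter) is expected to stay within the usual scatter, in neither direction. Compound 4 is therefore estimated at 5.5 ug/mL, most likely between 2 ug/mL and 16 ug/mL.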

Compound 4, half-maximal inhibitory concentration: > 100 ug/mL
Compound 4 gave a limit, no number (the forecaster's own chance of this, stated with the estimate: 10%); at least 18-fold (1.25 log units) between middle value and limit.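

In this assay, putting 2,4-dichlorophenyl in place of 2-fluorophenyl on a carbonyl carbon, with the rest of the structure unchanged, gives an at least 16-fold higher number from compound 3 to compound 4 (1.21 log units; beyond the scatter). For the compounds shown here, this is the first pair differing in one place, and it shows that this single position can separate a measured number from a limit of the assay. Compound 4 therefore joins the other compounds at that limit: the limit of > 100 ug/mL in this assay, at which 3 of the 4 values shown sit.

On these data alone, how a plain phenyl or a 4-methoxyphenyl on the same carbonyl carbon would read remains open. So does whether one chlorine alone would give the same result.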